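Bromo in Place of Trifluoromethyl: Expected Effect on Cell Inhibition

A few compounds are considered here, and "the series" means these few. Any claim that something is new, unique, unknown or untested is made for them only; others in the source may bear on it.

Measured so far:
Compound 1 `COc1cc(NC(=O)Nc2cc(Nc3ccc(C)c(F)c3)ncn2)cc(OC)c1`: 72%
Compound 2 `COc1cc(NC(=O)Nc2cc(Nc3cc(C(F)(F)F)ccc3OC)ncn2)cc(OC)c1`: 59.7%

In a functional assay on HCC827 cells (Homo sapiens) for inhibition, read by MTT assay, with a stated time of 48 h, tested at 10 uM (on this read-out higher numbers stand for more inhibition at the one concentration tested (going by the name of the read-out) and lower numbers for less inhibition), compound 1 gives 72%. In the same test compound 2 gives 59.7%, which is the lower of the two numbers. The gap between compound 1 and compound 2 lies beyond the usual scatter of repeated measurements.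

Compound 3 `COc1cc(NC(=O)Nc2cc(Nc3cc(Br)ccc3OC)ncn2)cc(OC)c1` has not yet been measured. It differs from compound 2 by bromo in place of trifluoromethyl on an aromatic carbon. Among the compounds with values here, no measured pair in this set shows that exchange, so there is nothing here to tell how large a step it brings. Within the data shown here, with only two numbers and no comparable step, a change within the scatter in either direction is expected, and the expected step from compound 2 to compound 3 is a number 0.3 percentage points higher from compound 2 to compound 3 (within the scatter). Compound 3 is therefore estimated at 60%, with a range from 42% to 78%.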

Compound 3, a percentage reported as inhibition, at one concentration (the size of the read-out at that concentration, not a potency): 76.3%
Beside the measured number, compound 3's estimate is 16.3 percentage points below it, within the range that was stated.
By their numbers in this assay, from the lowest: compound 2; then compounds 1 and 3 (each within the scatter of the next).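

In this assay, bromo in place of trifluoromethyl on this aromatic carbon, para to a methoxy group, gives a number 16.6 percentage points higher from compound 2 to compound 3 (beyond the scatter) and so shows that the group at this position can change the read-out, here with one heavy atom taking the place of four. With bromo in place, the comparison of 5-bromo-2-methoxyphenyl with 3-fluoro-4-methylphenyl on the nitrogen gives a number 4.3 percentage points higher from compound 1 to compound 3 (within the scatter) and so does not separate these two groups in this test, which compound 2 alone did not show. Nothing at hand accounts for the step at this position.

The compounds shown leave open how a nitrile, an amine or a chloro group on the same carbon would read in this assay. They also leave open whether the step from trifluoromethyl to bromo would hold with another group on the shared core.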